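Trimethoxybenzoyl hydrazone series: chloro in place of nitro

The source may report more compounds than this note shows. Statements on the series, on what has been measured and on what is new or still open speak of the compounds shown alone.

Of the compounds shown here, three have numbers so far. Compound 1 `COc1cc(C(=O)N/N=C/c2ccc(F)c(F)c2)cc(OC)c1OC` gives 43.7% in a functional assay on PC-3 cells (Homo sapiens) for antiproliferative activity, read by MTT assay, tested at 5 uM; on this read-out higher numbers stand for a stronger effect at the one concentration tested and lower numbers for a weaker effect. Compound 2 `COc1cc(C2=NN(C(C)=O)C(c3ccccc3C(F)(F)F)O2)cc(OC)c1OC` gives 15.2% in this assay. Compound 3 `COc1cc(C(=O)N/N=C/c2ccc(Cl)c([N+](=O)[O-])c2)cc(OC)c1OC` gives 42.3% in this assay. On these three numbers compound 3 stands second highest; its nearest neighbour is compound 1, whose number lies within the scatter of it, and its furthest is compound 2, whose number lies beyond the scatter below it. Going by the values given here, no pair of measured compounds differs in only one place, so no measured step is available.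

Compound 4 `COc1cc(C(=O)N/N=C/c2ccc(Cl)c(Cl)c2)cc(OC)c1OC` has not yet been measured. Against compound 3 the change is small: chloro in place of nitro on an aromatic carbon. Both measured hydrazones of the series sit close together, compound 1 giving 43.7% with a pair of fluoro groups where compound 3 carries chloro and nitro, so a second halogen in place of the nitro is not expected to move the number far. The step of a number 0.3 percentage points lower from compound 3 to compound 4 (within the scatter) is expected to be none beyond the scatter, with no clear direction. Compound 4 is therefore expected to give 42%, with a range from 28% to 56%.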

Compound 4, a percentage reported as inhibition, at one concentration (the size of the read-out at that concentration, not a potency): 31.6%
For compound 4 the middle estimate is 10.4 percentage points above the measured one, and the stated range covers the measured number.
By their numbers in this assay, from the lowest: compound 2; then compound 4; then compounds 3 and 1 (each within the scatter of the next).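

In this assay, chloro in place of nitro on an aromatic carbon gives a number 10.7 percentage points lower from compound 3 to compound 4 (beyond the scatter), so this position, ortho to a chloro group and meta to a large group, is not indifferent to the group it carries, as the close values of compound 1 and compound 3 alone might have suggested. The second comparison points the same way: 3,4-dichlorophenyl in place of 3,4-difluorophenyl on a carbon with a double bond to nitrogen gives a number 12.1 percentage points lower from compound 1 to compound 4 (beyond the scatter), which sets the dichloro pattern apart from both the difluoro pattern and the chloro and nitro pattern, though only among these three hydrazones and only at the single concentration tested. Nothing available on these compounds accounts for either step.

Still open, going by these compounds, is whether the drop belongs to chloro specifically or would follow other replacements of nitro at this position, such as an amine, a nitrile or a carboxylic acid. Also open, on these data alone, is whether the same change would produce a comparable step on the core of compound 2.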